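The source may hold more compounds than are shown below. What is called first, only, known or untested is meant among the compounds shown, and "the series" means these compounds.

The series is followed in a functional assay on KB3 cells (Homo sapiens) for antiproliferative activity, read by MTT assay, with a stated time of 96 h; on this read-out lower numbers stand for stronger inhibition and higher numbers for weaker inhibition. Among the compounds with values here, compound 2 `C=C(C)[C@H]1CC=C(C)C2=CO[C@@H](c3ccccc3F)[C@@H]21` gives 1000 nM in this assay, and this is the only number so far. Compound 1 `C=C(C)[C@H]1CC=C(C)[C@H]2[C@@H]1[C@H](c1ccccc1Br)O[C@@H]2C(=O)OCC` is reported in this assay only as a limit, > 100000 nM, not as a number. Within the data shown here, of the two values shown, one sits at the limit of > 100000 nM in this assay, at which 1 of the 2 values shown sits, so compound 2 stands alone as a measured number and no step between measured compounds can be drawn.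

Compound 3 `C=C(C)[C@H]1CC=C(C)C2=CO[C@@H](c3ccccc3Br)[C@@H]21` is not yet measured in this assay. It differs from compound 2 by bromo in place of fluoro on an aromatic carbon. Compound 1 also carries a bromo group, but its core differs from that of compound 2 in more than one place, so its limit says nothing on its own about this exchange. For bromo in place of fluoro here, no change beyond the scatter is expected in either direction, and the estimated step is no change at the digits printed from compound 2 to compound 3 (within the scatter). Compound 3 is therefore expected to give 1000 nM in this assay, with an expected range from 300 nM to 3500 nM.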

Compound 3, half-maximal inhibitory concentration: 4000 nM
Compound 3: the middle estimate sits 4.0-fold (0.60 log units) below what was measured, and the stated range ends below it.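

In this assay, the aromatic carbon ortho to a large group is not indifferent to which halogen it carries: bromo in place of fluoro gives a 4.0-fold higher number from compound 2 to compound 3 (0.60 log units; beyond the scatter). Within the data shown here, this is the first step that can be read, and with the shared core held fixed it gives the position a direction, with fluoro carrying the lower number and so the stronger inhibition of the two halogens. Nothing measured on these compounds speaks to a cause for this step.

A single exchange between two halogens leaves open whether another group on this carbon, such as chloro, methoxy or an amine, would continue the same direction, and whether the same exchange would give a similar step elsewhere on the aromatic ring. Compound 1 remains a limit, > 100000 nM, not a number, and its core differs from the shared core in more than one place, so how bromo behaves on that core stays unresolved.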